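Replacing methoxyphenyl by methylphenyl on the ring nitrogen

The compounds below may be only part of what the source reports. "The series", "measured", "known", "first", "only" and "open" are said of these compounds alone.

Measured compounds in a functional assay, read by spectrophotometry, with a stated time of 2 h, tested at 2 mg/mL; on this read-out lower numbers stand for a weaker effect and higher numbers for a stronger effect at the one concentration tested:
compound 1 `CC(C)[C@@H]1CC[C@@H](C)C[C@@]12N(C)C(=O)[C@@H]1[C@H]3C(=O)N(C)C(=O)[C@H]3ON12` gives 59.9%
compound 2 `CC(C)[C@@H]1CC[C@@H](C)C[C@@]12N(C)C(=O)[C@@H]1[C@H]3C(=O)N(c4ccccc4)C(=O)[C@H]3ON12` gives 41%
compound 3 `COc1ccc(N2C(=O)[C@H]3[C@H](ON4[C@@H]3C(=O)N(C)[C@@]43C[C@H](C)CC[C@H]3C(C)C)C2=O)cc1` gives 68.9%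

Compound 3 has the highest of the three numbers, with compound 1 within the usual scatter of it and compound 2 further off, so compound 3 cannot be called the most active of the set. Compound 4 `Cc1cccc(N2C(=O)[C@H]3[C@H](ON4[C@@H]3C(=O)N(C)[C@@]43C[C@H](C)CC[C@H]3C(C)C)C2=O)c1` differs from compound 3 in one place: 3-methylphenyl in place of 4-methoxyphenyl on an amide-type nitrogen in a ring. Going by the values given here, three steps bear on this change. Phenyl in place of methyl gave a number 18.9 percentage points lower from compound 1 to compound 2 (beyond the scatter), 4-methoxyphenyl in place of methyl gave a number 9 percentage points higher from compound 1 to compound 3 (within the scatter), and methoxy in place of hydrogen on the aromatic carbon gave a number 27.9 percentage points higher from compound 2 to compound 3 (beyond the scatter). Among the compounds with values here, compound 4 loses that methoxy and instead carries a methyl on the aromatic ring; no measured compound shows what such a methyl does. The loss of the methoxy alone points back toward compound 2, so a drop beyond the scatter is expected, though probably smaller than a full return. Compound 4 is therefore estimated at 50% (range 36% to 66%). This estimate means an expected step of a number 18.9 percentage points lower from compound 3 to compound 4 (beyond the scatter).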

Compound 4, a percentage reported as activity, at one concentration (the size of the read-out at that concentration, not a potency): 35.3%
Compound 4: middle estimate off by 14.7 percentage points, on the high side; the measured number lies below the stated range.
By their numbers in this assay, from the lowest: compounds 4 and 2 (each within the scatter of the next); then compounds 1 and 3 (each within the scatter of the next).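

In this assay, 3-methylphenyl in place of 4-methoxyphenyl gave a number 33.6 percentage points lower from compound 3 to compound 4 (beyond the scatter), the largest step yet seen on this amide-type nitrogen, so the number here depends strongly on what the aromatic ring carries. Methyl in place of hydrogen on an aromatic carbon gave a number 5.7 percentage points lower from compound 2 to compound 4 (within the scatter), so this methyl does not recover what the 4-methoxy group gave to compound 3, and compound 4 reads like the unsubstituted phenyl of compound 2. 3-Methylphenyl in place of methyl gave a number 24.6 percentage points lower from compound 1 to compound 4 (beyond the scatter), which matches the phenyl of compound 2, while compound 3 goes against this and stays within the scatter of compound 1.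

Still open, from the compounds shown here alone, is whether the methoxy group itself or its place on the ring matters, which 3-methoxyphenyl and 4-methylphenyl would separate. Nothing shown explains any of these steps.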